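Replacing an oxygen-linked nitroaryl group by a carbon-linked nitrile

The source may report more compounds than this note shows. Statements on the series, on what has been measured and on what is new or still open speak of the compounds shown alone.

Of the compounds shown here, three sharing one core have been tested in an assay for inhibition of prostacyclin synthase (Homo sapiens), using microsomes; a higher number here means a weaker inhibitor, a lower number a stronger inhibitor. Compound 1 `Cc1ccc(OC(C)(C)C2OCC(C/C=C\CCC(=O)O)C(c3cccnc3)O2)cc1` gives 25000 nM. Compound 2 `CC(C)(Oc1ccccc1O)C1OCC(C/C=C\CCC(=O)O)C(c2cccnc2)O1` reaches only the limit of the assay, > 100000 nM, and no number is known for it. Compound 3 `CC(C)(Oc1ccc(F)cc1[N+](=O)[O-])C1OCC(C/C=C\CCC(=O)O)C(c2cccnc2)O1` gives 9000 nM, the lowest number seen, with compound 1 nearest at a 2.8-fold lower number from compound 1 to compound 3 (0.44 log units; beyond the scatter); the change from compound 2 gives an at least 11-fold lower number from compound 2 to compound 3 (1.04 log units; beyond the scatter).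

Compound 4 `CC(C)(Cc1ccc(F)cc1C#N)C1OCC(C/C=C\CCC(=O)O)C(c2cccnc2)O1` arises from compound 3 by a group of 10 heavy atoms (8 carbon, 1 nitrogen, 1 fluorine; one six-membered aromatic ring of carbon only) in place of a group of 11 heavy atoms (6 carbon, 1 nitrogen, 3 oxygen, 1 fluorine; one six-membered aromatic ring of carbon only), on a saturated chain carbon bound to two saturated chain carbons and a saturated ring carbon. The measured steps all swap one aryl group for another on the oxygen of the core, and they range from at least modest to large. None of them removes the oxygen itself or exchanges a nitro group for a nitrile, so they bear on this step only loosely. A step of modest size is therefore expected in this assay, with its direction open. For compound 4 the estimate is 15000 nM, within a range from 3000 nM to 80000 nM, which implies a 1.7-fold higher number from compound 3 to compound 4 (0.22 log units; within the scatter).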

Compound 4, half-maximal inhibitory concentration: 7000 nM
Estimate against measurement, compound 4: 2.1-fold (0.33 log units) above; low and high end bracket the measured number.
By their numbers in this assay, from the lowest: compounds 4 and 3 (each within the scatter of the next); then compound 1. At a limit, above all of these: compound 2.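

The earlier compounds shown here all kept the oxygen on this saturated chain carbon, and here a carbon-linked aryl group carrying a nitrile replaces the oxygen-linked one carrying a nitro group with no change that can be told from the scatter in this assay: a 1.3-fold lower number from compound 3 to compound 4 (0.11 log units; within the scatter). The difference from the 4-methylphenyl group remains, with a 3.6-fold lower number from compound 1 to compound 4 (0.55 log units; beyond the scatter), and the difference from the 2-hydroxyphenyl group remains as well, with an at least 14-fold lower number from compound 2 to compound 4 (1.15 log units; beyond the scatter). Compound 2 has a limit and not a number: the limit of > 100000 nM in this assay, at which 1 of the 4 values shown sits.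

As far as these compounds go, the oxygen and the nitro group change in a single step, so their separate contributions stay unknown, and only a carbon-linked nitro compound or an oxygen-linked nitrile could divide them. From the compounds shown here alone, whether an amide or a trifluoromethyl group could take the place of the nitrile also stays open.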